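A few compounds are considered here, and "the series" means these few. Any claim that something is new, unique, unknown or untested is made for them only; others in the source may bear on it.

Working notes on the series. Of the compounds shown here, three share the trimethoxyphenyl core and have been measured in a functional assay on KYSE-450 cells (Homo sapiens) for inhibition, read by MTT assay, with a stated time of 48 h; on this read-out lower numbers stand for stronger inhibition and higher numbers for weaker inhibition. Compound 1 `COC(=O)c1cc(CNc2cc(OC)c(OC)c(OC)c2)ccc1OC` gives 41100 nM in this assay. Compound 2 `C/C=C/C(=O)N(Cc1ccc(OC)c(Br)c1)c1cc(OC)c(OC)c(OC)c1` gives 10500 nM in this assay. Going by the values given here, compound 3 `COc1ccc(CN(C(=O)CCCCCl)c2cc(OC)c(OC)c(OC)c2)cc1O` gives 770 nM in this assay, the lowest number of the three, with the gaps to compound 2 and to compound 1 both beyond the scatter, so compound 3 is the most potent compound measured so far.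

Compound 4 `CC/C=C/C(=O)N(Cc1ccc(OC)c(O)c1)c1cc(OC)c(OC)c(OC)c1` has not yet been measured. It differs from compound 3 in one place: but-1-en-1-yl in place of 4-chlorobutyl on a carbonyl carbon. The amide nitrogen, the benzyl part and the core are otherwise unchanged from compound 3. Among the compounds with values here, no step between measured compounds isolates this kind of change, so the expectation rests on the potency of compound 3 alone and on the weaker result of compound 2, which also carries an unsaturated acyl group on a different benzyl part.

For compound 4 a moderate loss beyond the scatter is expected in this assay, a step of a 2.6-fold higher number from compound 3 to compound 4 (0.41 log units; beyond the scatter). Compound 4 is therefore estimated at 2000 nM, with a range from 500 nM to 8000 nM.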

Compound 4, half-maximal inhibitory concentration: 72 nM
For compound 4 the middle estimate is 28-fold (1.44 log units) above the measured one; the whole stated range lies above it.
By their numbers in this assay, from the lowest: compound 4; then compound 3; then compound 2; then compound 1.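

The carbonyl substituent on the amide nitrogen proves to be a strong determinant of potency: with the benzyl part and the core held constant, but-1-en-1-yl in place of 4-chlorobutyl gives an 11-fold lower number from compound 3 to compound 4 (1.03 log units; beyond the scatter) in this assay. Going by these compounds alone, the earlier compounds offered no single-place step at this position, so this is the first direct reading of its effect, and the change favours the unsaturated chain. Within the data shown here, the single step combines the loss of chlorine with the gain of a double bond, and nothing available explains the gain in potency.

The compounds shown leave open whether the double bond or the absence of chlorine carries the effect, which a saturated butyl group would help separate. Also open, as far as these compounds go, is how a longer unsaturated chain or a terminal amine would fare at this position.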